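Dropping the 4-methylphenyl group from compound 3

The source may hold more compounds than are shown below. What is called first, only, known or untested is meant among the compounds shown, and "the series" means these compounds.

In a functional assay on HeLa cells (Homo sapiens) for inhibition, read by cell counting, with a stated time of 96 h (on this read-out lower numbers stand for stronger inhibition and higher numbers for weaker inhibition), compound 1 (`CCN(CC)CN1C(=O)/C(=N/NC(=S)Nc2ccc(Cl)cc2)c2ccccc21`) gives 7600 nM, compound 2 (`CCN(CC)CN1C(=O)/C(=N/NC(=S)Nc2ccc(OC)cc2)c2ccccc21`) gives 4400 nM and compound 3 (`CCN(CC)CN1C(=O)/C(=N/NC(=S)Nc2ccc(C)cc2)c2ccccc21`) gives 12000 nM. The standing of compound 3 rests on two steps: a 1.6-fold higher number from compound 1 to compound 3 (0.20 log units; within the scatter) and a 2.7-fold higher number from compound 2 to compound 3 (0.44 log units; beyond the scatter). It is therefore separated only from compound 2.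

Compound 4 (`CCN(CC)CN1C(=O)/C(=N/NC(N)=S)c2ccccc21`) has hydrogen in place of 4-methylphenyl on an amide-type nitrogen. The measured steps, including a 1.7-fold lower number from compound 1 to compound 2 (0.24 log units; within the scatter), only exchange a substituent on the aromatic ring. None removes the ring, so they give no direct size for this change, and the direction below is a weakly founded expectation. The expected change is a 2.1-fold higher number from compound 3 to compound 4 (0.32 log units; beyond the scatter). For compound 4 the estimated value is 25000 nM, with an expected range of 8000 nM to 80000 nM.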

Compound 4, half-maximal inhibitory concentration: 123000 nM
For compound 4 the middle estimate is 4.9-fold (0.69 log units) below the measured one; measured number above the stated range.
By their numbers in this assay, from the lowest: compounds 2, 1 and 3 (each within the scatter of the next, the first and the last beyond it); then compound 4.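

In this assay, the aryl group on the amide-type nitrogen carries far more weight than the substituent on that ring: replacing it with hydrogen gives a 10-fold higher number from compound 3 to compound 4 (1.01 log units; beyond the scatter) and a 28-fold higher number from compound 2 to compound 4 (1.45 log units; beyond the scatter) and a 16-fold higher number from compound 1 to compound 4 (1.21 log units; beyond the scatter) in the same direction, whichever aryl group leaves. The largest step among the ring substituent exchanges is only a 2.7-fold higher number from compound 2 to compound 3 (0.44 log units; beyond the scatter) by comparison. Nothing measured here explains the loss.

Open, from the compounds shown here alone, is whether the aromatic ring itself is required. Methyl, cyclohexyl or benzyl on that nitrogen would separate the ring from mere substitution.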